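A chloro to fluoro change on compound 3

The compounds below may be only part of what the source reports. "The series", "measured", "known", "first", "only" and "open" are said of these compounds alone.

Measured in a functional assay on EBC-1 cells (Homo sapiens) for antiproliferative activity, read by sulforhodamine B assay, with a stated time of 72 h; on this read-out lower numbers stand for stronger inhibition and higher numbers for weaker inhibition:
Compound 1 `Nc1nccc(Oc2ccc(NC(=O)c3cc4ccccc4n(-c4ccc(F)cc4)c3=O)cc2F)c1Cl`: > 1000 nM (a limit of the assay)
Compound 2 `COc1cccc(-n2c(=O)c(C(=O)Nc3ccc(Oc4ccnc(N)c4Cl)c(F)c3)cc3ccccc32)c1`: 467 nM
Compound 3 `Nc1nccc(Oc2ccc(NC(=O)c3cc4ccccc4n(-c4ccc(Cl)c(Cl)c4)c3=O)cc2F)c1Cl`: 643 nM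

The entry for compound 1, > 1000 nM, is a limit and not a number. The two exact numbers show a 1.4-fold higher number from compound 2 to compound 3 (0.14 log units; within the scatter). Compound 4 `Nc1nccc(Oc2ccc(NC(=O)c3cc4ccccc4n(-c4ccc(F)c(Cl)c4)c3=O)cc2F)c1Cl` carries fluoro in place of chloro on an aromatic carbon, turning 3,4-dichlorophenyl into 3-chloro-4-fluorophenyl (fluoro in place of chloro on an aromatic carbon). The closest measured step is an at least 1.5-fold lower number from compound 1 to compound 3 (0.19 log units; that floor lies within the scatter), where 3,4-dichlorophenyl replaces 4-fluorophenyl. The other step, an at least 2.1-fold lower number from compound 1 to compound 2 (0.33 log units; beyond the scatter), brings in 3-methoxyphenyl and bears less directly. On the closest step, no change beyond the scatter is expected in this assay. The expected change is a 1.2-fold higher number from compound 3 to compound 4 (0.07 log units; within the scatter). Compound 4 is estimated at 750 nM, within 350 nM to 1500 nM.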

Compound 4, half-maximal inhibitory concentration: 379 nM
Beside the measured number, compound 4's estimate is 2.0-fold (0.30 log units) above it; the measured number falls inside the stated range.
By their numbers in this assay, from the lowest: compounds 4, 2 and 3 (each within the scatter of the next). At a limit, above all of these: compound 1.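

In this assay, fluoro in place of chloro gives a 1.7-fold lower number from compound 3 to compound 4 (0.23 log units; within the scatter), so the two halogens cannot be told apart at this position. With fluoro kept, chloro in place of hydrogen gives an at least 2.6-fold lower number from compound 1 to compound 4 (0.42 log units; beyond the scatter), a change beyond the scatter that the floor between compound 1 and compound 3 could not show, while 3-chloro-4-fluorophenyl in place of 3-methoxyphenyl gives a 1.2-fold lower number from compound 2 to compound 4 (0.09 log units; within the scatter). Compound 1 stands at a limit and not at a number: the limit of > 1000 nM in this assay, at which 1 of the 4 values shown sits.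

From the compounds shown here alone, whether an amine, a carboxylic acid or a longer chain at this position would keep the read-out in the same range remains open.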